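This account rests on a few compounds, and the source may have more. Where it says the series, first, only, none or still open, it means among the compounds named here.

Working notes on the series. Compound 1 `CC(C)=CCC/C(C)=C/CC/C(C)=C/CC[C@]1(C)CCc2cc(OC(=O)NS(=O)(=O)c3ccc(Cl)cc3)cc(C)c2O1`, compound 2 `CC(C)=CCC/C(C)=C/CC/C(C)=C/CC[C@]1(C)CCc2cc(OC(=O)NC(=O)Oc3ccccc3)cc(C)c2O1` and compound 3 `CC(C)=CCC/C(C)=C/CC/C(C)=C/CC[C@]1(C)CCc2cc(OC(=O)Nc3ccccc3)c(C)c(C)c2O1` share the same core and differ in the group attached to the carbamate nitrogen. In a functional assay on MDA-MB-231 cells (Homo sapiens) for antiproliferative activity, read by MTT assay, with a stated time of 96 h (a lower number here means a stronger inhibitor, a higher number a weaker inhibitor), compound 1 gives only a limit, > 10000 nM. Compound 3 likewise returns only a limit in this assay, > 10000 nM. Going by the values given here, for compound 2 the outcome in this assay is "not determined" (no result reported); compound 2 therefore stands without a number of its own, and the sole landmark among the values shown is the limit of > 10000 nM in this assay, at which 2 of the 3 values shown sit. Among the compounds with values here, no step between two measured compounds can be drawn from these data.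

Compound 4 `CC(C)=CCC/C(C)=C/CC/C(C)=C/CC[C@]1(C)CCc2cc(OC(=O)NCc3ccccc3)cc(C)c2O1` is the next member to be tested. It differs from compound 2 in a single place: benzyl in place of phenoxycarbonyl on an amide-type nitrogen. The six-membered aromatic ring of carbon is kept; the carbonyl and the oxygen that belonged to the phenoxycarbonyl group leave, so the hydrogen-bond acceptor count of that substituent drops to none.

Within the data shown here, with compound 2 unmeasured, no size of step in this assay can be anchored; the expectation is for no movement beyond the scatter, with the outcome most likely again at the limit. Compound 4 is accordingly expected to give about 15000 nM in this assay, within a range of 3000 nM to 60000 nM.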

Compound 4, half-maximal inhibitory concentration: > 10000 nM
Compound 4 was reported as a limit; the forecaster's own chance of this, stated with the estimate: 70%; the middle value does not contradict the limit.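

Going by these compounds alone, compound 1 and compound 4 both stand only as limits in this assay, and no step between them can be read: the limit of > 10000 nM in this assay, at which 3 of the 4 values shown sit. The compounds shown leave open whether any group on the carbamate nitrogen of the shared core gives a numerical value in this assay rather than a limit.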